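The source may hold more compounds than are shown below. What is called first, only, known or untested is meant among the compounds shown, and "the series" means these compounds.

Measured in a functional assay (trachea) with Cavia porcellus as the target; on this read-out higher numbers stand for weaker inhibition and lower numbers for stronger inhibition:
- compound 1 `CCn1nc(-c2cccnc2)c2ccccc2c1=O`: 1320 nM
- compound 2 `O=c1c2ccccc2c(-c2cccnc2)nn1C1CCCC1`: 2750 nM
- compound 3 `CC(=O)Cn1nc(-c2cccnc2)c2ccccc2c1=O`: 40700 nM

Compound 3 has the highest number of the three, which makes it the weakest inhibitor in this assay. Its gaps to the others are large: a 31-fold higher number from compound 1 to compound 3 (1.49 log units; beyond the scatter) and a 15-fold higher number from compound 2 to compound 3 (1.17 log units; beyond the scatter).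

Compound 4 `O=C(c1cccs1)n1nc(-c2cccnc2)c2ccccc2c1=O` keeps the shared core but carries (thiophen-2-yl)carbonyl in place of 2-oxopropyl on an aromatic nitrogen. Among the measured compounds shown here, no measured compound contains a thiophene, so no step shows this change directly, and any forecast is indirect.

Two pieces of evidence bear on it. Exchanging ethyl for the ring-bearing cyclopentyl changed the number only modestly, a 2.1-fold higher number from compound 1 to compound 2 (0.32 log units; beyond the scatter), so compound 2 shows that a ring on this nitrogen can go with a low number. Against that, compound 4 keeps a carbonyl in its new group, as compound 3 does, and compound 3 gave 40700 nM. The new group therefore resembles both a good and a poor neighbour.

A moderate move towards a lower number is expected, smaller than the large gaps above: a 4.5-fold lower number from compound 3 to compound 4 (0.66 log units; beyond the scatter). For compound 4 the estimated value is 9000 nM, with an expected range from 2000 nM to 40000 nM.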

Compound 4, half-maximal inhibitory concentration: 12300 nM
Compound 4: the middle estimate sits 1.4-fold (0.14 log units) below what was measured, within the range that was stated.
By their numbers in this assay, from the lowest: compound 1; then compound 2; then compound 4; then compound 3.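

In this assay, a group containing a carbonyl on this aromatic nitrogen does not have to give the highest number: exchanging 2-oxopropyl for (thiophen-2-yl)carbonyl lowers it (a 3.3-fold lower number from compound 3 to compound 4 (0.52 log units; beyond the scatter)). The carbonyl that both groups contain therefore does not fix the value on its own, and what surrounds it matters as well. Even so, the new group does not reach the level of the two groups without a carbonyl, as the number stays higher than with cyclopentyl (a 4.5-fold higher number from compound 2 to compound 4 (0.65 log units; beyond the scatter)) and higher than with ethyl (a 9.3-fold higher number from compound 1 to compound 4 (0.97 log units; beyond the scatter)). No measurement shown here explains why these groups differ.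

The compounds shown do not separate the part played by the thiophene ring from that of the carbonyl, a question that benzoyl or thiophen-2-ylmethyl on the same nitrogen would address. Also open, as far as these compounds go, are a longer chain such as butyl, a chain ending in an amine or a carboxylic acid, and any replacement of the pyridin-3-yl group, which all four compounds share.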